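Adding a Methoxy Group to a Mer Kinase Inhibitor

A few compounds are considered here, and "the series" means these few. Any claim that something is new, unique, unknown or untested is made for them only; others in the source may bear on it.

Within the data shown here, compound 2 `Cc1nn(C)c(C)c1-c1ccc(-c2nnc(N(C)Cc3ccc4nccn4c3)o2)cc1` is one of two compounds measured in an assay on isolated protein for inhibition of tyrosine-protein kinase Mer (Homo sapiens), read by LC-MS (a lower number here means a stronger inhibitor, a higher number a weaker inhibitor), where compound 2 gives 31.6 nM. Among the measured compounds shown here, the only comparison is compound 1 `CN(Cc1ccc2nccn2c1)c1nnc(-c2ccc(-c3ccccc3C#N)cc2)o1`, which in this assay gives 25.1 nM; the step of a 1.3-fold higher number from compound 1 to compound 2 (0.10 log units; within the scatter) lies within the scatter, so compound 2 stands level with compound 1. Compound 3 `COc1cc(-c2c(C)nn(C)c2C)ccc1-c1nnc(N(C)Cc2ccc3nccn3c2)o1` differs from compound 2 by a single change: methoxy in place of hydrogen on an aromatic carbon. For the measured compounds named here, no measured step involves a methoxy, and the one known step exchanged a whole aryl group, so it offers no direct guide. The step of a 1.0-fold higher number from compound 2 to compound 3 (0.01 log units; within the scatter) is therefore expected to stay within the scatter. Compound 3 is estimated at 32 nM, with a range from 10 nM to 100 nM.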

Compound 3, half-maximal inhibitory concentration: 15.9 nM
The estimate for compound 3 lay 2.0-fold (0.30 log units) above the measured number; low and high end bracket the measured number.
By their numbers in this assay, from the lowest: compounds 3, 1 and 2 (each within the scatter of the next).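

In this assay, methoxy in place of hydrogen on this aromatic carbon, ortho to a large group, gives a 2.0-fold lower number from compound 2 to compound 3 (0.30 log units; within the scatter), so the number stays level with that of the parent. This position therefore carries an added methoxy without a readable change in this assay, something the earlier swap of a whole aryl group could not show. Nothing measured here bears on why the number holds level.

From the compounds shown here alone, whether an amine or a carboxylic acid on the same carbon would move the number beyond the scatter remains open. Also open, going by these compounds, is whether methoxy would act alike with the 2-cyanophenyl group of compound 1.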